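A few compounds are considered here, and "the series" means these few. Any claim that something is new, unique, unknown or untested is made for them only; others in the source may bear on it.

Measured so far in a functional assay (trachea) for antagonist activity, with Cavia porcellus as the target; on this read-out lower numbers stand for lower potency and higher numbers for higher potency (the scale is a negative logarithm):
compound 1 `COc1ccc(OC)c(S(=O)(=O)NC(=O)c2ccc(Cn3ccc4ccc(NC(=O)CC5CCCC5)cc43)c(OC)c2)c1`, compound 1 gives 9.1
compound 2 `COc1cc(C(=O)NS(=O)(=O)c2cccs2)ccc1Cn1ccc2ccc(NC(=O)CC3CCCC3)cc21`, compound 2 gives 9.6
compound 3 `CCCCOC(=O)Nc1ccc2cnn(Cc3ccc(C(=O)NS(=O)(=O)c4ccccc4)cc3OC)c2c1`, compound 3 gives 9.2

Compound 2 stands highest of the three in this assay; compound 3 is nearest, lower by a margin beyond the scatter, and compound 1 is furthest, also lower beyond the scatter. Compound 4 `COc1cc(C(=O)NS(=O)(=O)c2cc(C)ccc2C)ccc1Cn1ccc2ccc(NC(=O)CC3CCCC3)cc21` is not yet measured. Its change from compound 2 is 2,5-dimethylphenyl in place of thiophen-2-yl on a sulfonyl sulfur. Within the data shown here, the one measured step that bears on this place is a number 0.50 log units higher from compound 1 to compound 2 (beyond the scatter), in which a thiophen-2-yl took the place of a 2,5-dimethoxyphenyl on the sulfonyl sulfur. Compound 4 goes the other way, putting a six-membered carbon-only ring back on the sulfonyl sulfur, now carrying two methyls rather than two methoxys; compound 3, with a phenyl there on a different core, also sits below compound 2. A modest step down in this assay is therefore expected, a number 0.40 log units lower from compound 2 to compound 4 (beyond the scatter). Compound 4 is estimated at 9.2, in the range 8.7 to 9.7.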

Compound 4, negative logarithm of the antagonist equilibrium constant: 8.4
Beside the measured number, compound 4's estimate is 0.80 log units above it, outside the stated range (below it).
By their numbers in this assay, from the lowest: compound 4; then compounds 1 and 3 (each within the scatter of the next); then compound 2.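

In this assay, among these compounds, the group on the sulfonyl sulfur matters more than the first step at this place showed: 2,5-dimethylphenyl in place of thiophen-2-yl gives a number 1.20 log units lower from compound 2 to compound 4 (beyond the scatter), a step printed as large. A six-membered aromatic ring of carbon only does not fix the number on its own, as 2,5-dimethylphenyl in place of 2,5-dimethoxyphenyl gives a number 0.70 log units lower from compound 1 to compound 4 (beyond the scatter), so the two groups on that ring also count. Nothing measured here accounts for either step.

Still open, going by these compounds, is how an unsubstituted phenyl would read on the shared core, as compound 3 carries phenyl on a different core. Also open, on these data alone, is how a pyridine ring, a cyclohexyl ring or a propyl chain on the sulfonyl sulfur would compare with thiophen-2-yl.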